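The source may hold more compounds than are shown below. What is called first, only, known or untested is meant among the compounds shown, and "the series" means these compounds.

Measured so far in a functional assay on MDA-MB-231 cells (Homo sapiens) for antiproliferative activity, read by MTT assay, with a stated time of 72 h; on this read-out lower numbers stand for stronger inhibition and higher numbers for weaker inhibition:
Compound 1 `CC(=O)Nc1ccc(S(=O)(=O)Nc2cccc(-c3nc(-c4ccc(NC(=O)c5cccnc5)cc4Cl)no3)c2)cc1` gives 2500 nM.
Compound 2 `CC(=O)Nc1ccc(S(=O)(=O)Nc2cccc(-c3nc(-c4ccc(NC(=O)c5cccnc5)cc4)no3)c2)cc1` gives 5200 nM.
Compound 3 `CS(=O)(=O)Nc1ccc(NC(=O)Nc2cccc(-c3nc(-c4ccc(NC(=O)c5cccnc5)cc4Cl)no3)c2)cc1` gives 600 nM.

Compound 3 stands lowest of the three, with compound 1 nearest to it and compound 2 furthest away. Between compound 2 and compound 1 the difference is chloro in place of hydrogen on an aromatic carbon, and it brought a 2.1-fold lower number from compound 2 to compound 1 (0.32 log units; beyond the scatter). How the core of compound 3 differs from that of compound 2 is not broken down here.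

Compound 4 `CS(=O)(=O)Nc1ccc(NC(=O)Nc2cccc(-c3nc(-c4ccc(NC(=O)c5cccnc5)cc4Cl)no3)c2)cc1Cl` has not yet been measured. It differs from compound 3 by chloro in place of hydrogen on an aromatic carbon. This is the same kind of change as that from compound 2 to compound 1, but not the same: in compound 1 the chloro sits ortho to a large group and meta to a ((pyridin-3-yl)carbonyl)amino group, whereas in compound 4 it sits ortho to a methanesulfonamido group and meta to a large group. Resting on compound 3 at 600 nM and on the earlier step of a 2.1-fold lower number from compound 2 to compound 1 (0.32 log units; beyond the scatter), the expected step is a 1.5-fold lower number from compound 3 to compound 4 (0.18 log units; within the scatter). Compound 4 is thus estimated to give 400 nM in this assay, most likely between 150 nM and 1200 nM.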

Compound 4, half-maximal inhibitory concentration: 600 nM
Beside the measured number, compound 4's estimate is 1.5-fold (0.18 log units) below it, and the stated range covers the measured number.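

In this assay, chloro in place of hydrogen on the 4-(methanesulfonamido)phenyl group brought no change at the digits printed from compound 3 to compound 4 (within the scatter). Set beside the earlier chloro step on the other core, this result does not differ from it beyond what repeated measurement allows: the same change on two cores in this assay, a 2.1-fold lower number (0.32 log units; beyond the scatter) from compound 2 to compound 1 and no change at the digits printed (within the scatter) from compound 3 to compound 4, 2.1-fold (0.32 log units) apart, within the scatter of two such steps. Going by these compounds alone, the pair of steps therefore gives no sign that the change behaves differently on these two cores, but it does not show that the change carries over: there is only one step per core, the chloro sits at a different place in each, and one of the two steps is itself within the scatter.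

The compounds shown leave open whether fluoro, methyl or methoxy at the same place on the core of compound 3 would shift the number. They also leave open what an amine or a carboxylic acid in place of the methanesulfonamido group would do in this assay.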